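The compounds below may be only part of what the source reports. "The series", "measured", "known", "first", "only" and "open" are said of these compounds alone.

Among the measured compounds shown here, in a functional assay on ECa-109 cells for inhibition, with ECa-109 cell line (Homo sapiens) as the target, read by sulforhodamine B assay (on this read-out higher numbers stand for weaker inhibition and lower numbers for stronger inhibition), compound 2 (`CCc1ccc(NC2=CC(=O)c3nc4n(c3C2=O)[C@H]2OC[C@@H](O)[C@H]2OC4)cc1`) gives 3080 nM, the only actual number among the measured compounds. Compound 1 (`CCc1ccc(NC2=CC(=O)c3c(nc4n3[C@H]3OC[C@@H](O)[C@H]3OC4)C2=O)cc1`) returns > 4000 nM, which is a limit of the assay and not a number. For the measured compounds named here, one number and one limit provide no measured step to go by. Compound 3 (`COc1ccc(NC2=CC(=O)c3nc4n(c3C2=O)[C@H]2OC[C@@H](O)[C@H]2OC4)cc1`) has methoxy in place of ethyl on an aromatic carbon, para to a large group: methoxy in place of ethyl on an aromatic carbon. Going by the values given here, with no measured precedent for this change, no shift beyond the usual scatter is expected in either direction in this assay, and the expectation is anchored on compound 2 at 3080 nM. The expected step is small, an estimated 1.0-fold lower number from compound 2 to compound 3 (0.01 log units; within the scatter). Compound 3 is expected at about 3000 nM, with an estimated range of 1200 nM to 7000 nM.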

Compound 3, half-maximal inhibitory concentration: > 4000 nM
Compound 3 gave a limit, no number (the forecaster's own chance of this, stated with the estimate: 25%); at least 1.3-fold (0.12 log units) between middle value and limit.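

Among the compounds shown here, putting methoxy in place of ethyl on this aromatic carbon, para to a large group, gives the first step that can be read at this position in this assay, and it is an at least 1.2-fold higher number from compound 2 to compound 3 (0.11 log units; that floor lies within the scatter). As far as these compounds go, the value of compound 3, > 4000 nM, is a limit of the assay and not a number, so the step gives only a floor and its full size stays unknown. The read-out therefore shows no gain from methoxy, and it has little room to separate these compounds: the limit of > 4000 nM in this assay, at which 2 of the 3 values shown sit.

The compounds shown leave open whether another group at this position, such as an amine, a carboxylic acid or a chain longer than ethyl, would give a lower number than compound 2 does. They also leave open what methoxy would do on the core of compound 1.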